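The source may report more compounds than this note shows. Statements on the series, on what has been measured and on what is new or still open speak of the compounds shown alone.

Measured so far:
compound 1, `CCCCC/C=C/C=C/C=N/Nc1nc(N)c2ncn([C@@H]3O[C@H](CO)[C@@H](O)[C@H]3O)c2n1`, in an assay on CHO-K1 cells for displacement of a labelled ligand from adenosine receptor A1 (Homo sapiens), read by scintillation counting, with a stated time of 60 min (on this read-out lower numbers stand for stronger inhibition and higher numbers for weaker inhibition), gives 2 nM
compound 2, `Nc1nc(N/N=C/c2ccc(-c3ccc(Br)cc3)o2)nc2c1ncn2[C@@H]1O[C@H](CO)[C@@H](O)[C@H]1O`, in this assay gives 4.5 nM

Of the two numbers shown, compound 1 has the lower one, and its gap to compound 2 is beyond the usual scatter, so compound 1 stands as the stronger binder of the pair. Both share the same core and differ only in the group hung on the carbon with a double bond to nitrogen.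

The next compound is compound 3, `Nc1nc(N/N=C/C2CCCC2)nc2c1ncn2[C@@H]1O[C@H](CO)[C@@H](O)[C@H]1O`, which has not yet been measured in this assay. It differs from compound 1 in one place: a group of 5 heavy atoms (5 carbon; one five-membered non-aromatic ring of carbon only) in place of a group of 9 heavy atoms (9 carbon; no ring), on a carbon with a double bond to nitrogen

For the measured compounds named here, no measured pair isolates this change, so its size is not known from the data. The group that leaves compound 1 is the larger of the two, and compound 1 has the best value seen, so a move to a weaker number is expected rather than a gain. The step of a 10-fold higher number from compound 1 to compound 3 (1.00 log units; beyond the scatter) is the expected outcome. Compound 3 is estimated at 20 nM, with a range from 4 nM to 100 nM.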

Compound 3, inhibition constant: 5.6 nM
Beside the measured number, compound 3's estimate is 3.6-fold (0.55 log units) above it; low and high end bracket the measured number.
By their numbers in this assay, from the lowest: compound 1; then compounds 2 and 3 (each within the scatter of the next).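

At the carbon with a double bond to nitrogen, cyclopentyl in place of the open chain of 9 heavy atoms with its 2 double bonds gives a 2.8-fold higher number from compound 1 to compound 3 (0.45 log units; beyond the scatter) in this assay. For the compounds shown here, this is the first step measured at this position, and it shows that the open chain can be replaced by a much smaller carbon ring at only a modest cost, with compound 3 still at 5.6 nM. Nothing measured here bears on why the number moves.

The two groups differ in ring, size and double bonds at once, so the compounds shown leave open which of these changes accounts for the step. On these data alone, it also stays open whether a pentyl chain, a cyclohexyl ring or an amine at this carbon would give a number closer to that of compound 1.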